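The source may hold more compounds than are shown below. What is called first, only, known or untested is meant among the compounds shown, and "the series" means these compounds.

Compound 1 `O=C(/C=C/c1cccc(O)c1O)CC(=O)/C=C/c1cccc(O)c1O` gives 30000 nM in a functional assay, with a stated time of 30 min; on this read-out lower numbers stand for stronger inhibition and higher numbers for weaker inhibition. Compound 2 `O=C(/C=C/c1ccccc1O)CC(=O)/C=C/c1cccc(O)c1O` gives 23000 nM in this assay. Compound 3 `O=C(/C=C/c1cccc(O)c1)CC(=O)/C=C/c1cc(O)ccc1O` gives 88000 nM in this assay.

The change from compound 2 to compound 1, (hydroxy in place of hydrogen on an aromatic carbon), gave a 1.3-fold higher number from compound 2 to compound 1 (0.12 log units; within the scatter). Compound 3 and compound 2 are built from the same atoms joined differently; the difference between the two cores is not broken down here. Compound 3 stands highest of the three measured values in this assay. Compound 4 `O=C(/C=C/c1cc(O)ccc1O)CC(=O)/C=C/c1cc(O)ccc1O` arises from compound 3 by hydroxy in place of hydrogen on an aromatic carbon. This is the same kind of change as that from compound 2 to compound 1, but the surroundings differ: there the new hydroxy sat ortho to a hydroxy group and meta to a large group, here it sits ortho to a large group and para to a hydroxy group. Resting on the earlier step of a 1.3-fold higher number from compound 2 to compound 1 (0.12 log units; within the scatter), a step of about a 1.0-fold higher number from compound 3 to compound 4 (0.01 log units; within the scatter) is expected, so compound 4 is estimated at 90000 nM in this assay, between 35000 nM and 230000 nM.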

Compound 4, half-maximal inhibitory concentration: 57000 nM
Compound 4: the middle estimate sits 1.6-fold (0.20 log units) above what was measured; low and high end bracket the measured number.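

In this assay, hydroxy in place of hydrogen on an aromatic carbon gave a 1.5-fold lower number from compound 3 to compound 4 (0.19 log units; within the scatter) on the core of compound 3. Set beside the earlier step, this result gives no sign that the core alters the outcome of the change: the same change on two cores in this assay, a 1.3-fold higher number (0.12 log units; within the scatter) from compound 2 to compound 1 and a 1.5-fold lower number (0.19 log units; within the scatter) from compound 3 to compound 4, 2.0-fold (0.30 log units) apart, within the scatter of two such steps. For the compounds shown here, both steps are small, so the two pairs show only that the change left the number within the scatter on both cores; they do not show that it would do so at other positions or on other cores.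

Every compound shown carries only hydroxy groups on its aromatic rings. As far as these compounds go, whether a methoxy group or a carboxylic acid on those rings, or a longer chain in the core, would move the number remains open.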